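The source may report more compounds than this note shows. Statements on the series, on what has been measured and on what is new or still open speak of the compounds shown alone.

Compound 1 `CC(C)(C)n1cc2c(n1)C(=O)CC1(CCN(C(=O)c3cc(-c4ccccc4Cl)nc4ccccc34)CC1)O2`: > 10000 nM, a limit
Compound 2 `COc1ccc(-c2cc(C(=O)N3CCC4(CC3)CC(=O)c3nn(C(C)(C)C)cc3O4)c3ccccc3n2)cc1OC`: 1560 nM
Compound 3 `CC(C)(C)n1cc2c(n1)C(=O)CC1(CCN(C(=O)c3cc(-c4ccccn4)nc4ccccc34)CC1)O2`: 1500 nM

In a functional assay on HepG2 cells (Homo sapiens) for inhibition, read by MTT assay, with a stated time of 72 h (a lower number here means a stronger inhibitor, a higher number a weaker inhibitor), compound 3 gives 1500 nM, and compound 2 lies within the scatter of it at 1560 nM. For compound 1 the assay reports a limit, > 10000 nM.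

Compound 4 `CN1CCN(c2cc(C(=O)N3CCC4(CC3)CC(=O)c3nn(C(C)(C)C)cc3O4)c3ccccc3n2)CC1` carries 4-methylpiperazin-1-yl in place of pyridin-2-yl on an aromatic carbon, next to the ring nitrogen: 4-methylpiperazin-1-yl in place of pyridin-2-yl on an aromatic carbon.

Three measured steps swap the group at this place. Two lie beyond the scatter: an at least 6.4-fold lower number from compound 1 to compound 2 (0.80 log units; beyond the scatter) and an at least 6.6-fold lower number from compound 1 to compound 3 (0.82 log units; beyond the scatter). Both leave 2-chlorophenyl behind, which compound 4 never carried. The third is closer to this case: a 1.0-fold lower number from compound 2 to compound 3 (0.02 log units; within the scatter).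

However, the entering ring is non-aromatic, unlike any measured here, so the range stays wide. The expected step, slightly upward and not clearly beyond the scatter, is a 1.7-fold higher number from compound 3 to compound 4 (0.22 log units; within the scatter). For compound 4 the estimated value is 2500 nM, with an expected range of 700 nM to 10000 nM.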

Compound 4, half-maximal inhibitory concentration: 9550 nM
The estimate for compound 4 lay 3.8-fold (0.58 log units) below the measured number; the range from low to high includes it.
By their numbers in this assay, from the lowest: compounds 3 and 2 (each within the scatter of the next); then compound 4. At a limit, above all of these: compound 1.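

In this assay the non-aromatic ring 4-methylpiperazin-1-yl gives a weaker inhibitor than pyridin-2-yl or 3,4-dimethoxyphenyl on this aromatic carbon, with a 6.4-fold higher number from compound 3 to compound 4 (0.80 log units; beyond the scatter) and a 6.1-fold higher number from compound 2 to compound 4 (0.79 log units; beyond the scatter) as the two steps. So this position does not treat every ring alike, though pyridin-2-yl and 3,4-dimethoxyphenyl stay within the scatter of each other. The remaining step, an at least 1.0-fold lower number from compound 1 to compound 4 (0.01 log units; that floor lies within the scatter), cannot be read, since compound 1 stands at a limit: the limit of > 10000 nM in this assay, at which 1 of the 4 values shown sits. As far as these compounds go, it stays open whether the higher number goes with the non-aromatic ring itself or with its methyl-bearing nitrogen, and a piperidine, a morpholine or an unsubstituted piperazine at this place would tell these apart.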